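Aryl-alkynyl phenoxyacetic acids: removing the dimethylcarbamoyl group

This account rests on a few compounds, and the source may have more. Where it says the series, first, only, none or still open, it means among the compounds named here.

Measured in an assay on CHO cells for displacement of a labelled ligand from prostaglandin D2 receptor 2 (Homo sapiens), read by scintillation counting; on this read-out higher numbers stand for weaker inhibition and lower numbers for stronger inhibition:
- compound 1 `CN(C)C(=O)c1cccc(C#Cc2cc(Cl)ccc2OCC(=O)O)c1`: 52 nM
- compound 2 `CC(C)Cc1ccncc1C#Cc1cc(Cl)ccc1OCC(=O)O`: 4.9 nM
- compound 3 `Cc1ccc(S(=O)(=O)N2CCN(C)CC2)cc1C#Cc1cc(Cl)ccc1OCC(=O)O`: 21 nM

Compound 1 stands at the high end of the three numbers in this assay: compound 3 sits nearest, with a lower number than compound 1 beyond the scatter, and compound 2 lies furthest, with a lower number than compound 1 that is well beyond the scatter. The three compounds share the chloro-substituted phenoxyacetic acid core with an alkyne linker, and differ only in the aromatic group at the far end of the alkyne.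

Compound 4 `O=C(O)COc1ccc(Cl)cc1C#Cc1ccccc1` has not yet been measured in this assay. It differs from compound 1 in one place: hydrogen in place of dimethylcarbamoyl on an aromatic carbon. Within the data shown here, nothing among the measured compounds shows what the unsubstituted aromatic ring does on this core, so the expectation rests on compound 1 alone. Since every measured variation of that ring carries a polar substituent, and compound 1 with its dimethylcarbamoyl already gives 52 nM, removing that group is expected to weaken binding by a moderate step, a 2.9-fold higher number from compound 1 to compound 4 (0.46 log units; beyond the scatter), with a wide range either side. Compound 4 is therefore estimated at 150 nM in this assay, with a likely span from 50 nM to 500 nM.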

Compound 4, inhibition constant: 108 nM
The estimate for compound 4 lay 1.4-fold (0.14 log units) above the measured number, within the range that was stated.
By their numbers in this assay, from the lowest: compound 2; then compound 3; then compound 1; then compound 4.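

In this assay, among these compounds, replacing dimethylcarbamoyl with hydrogen on this aromatic carbon, meta to a large group, gives a 2.1-fold higher number from compound 1 to compound 4 (0.32 log units; beyond the scatter), the first step that can be read at a single position. The step is beyond the scatter but modest, so dimethylcarbamoyl at this position improves inhibition only slightly, and the unsubstituted compound 4 still gives 108 nM, which shows that this group is not required for measurable inhibition. No measurement shown here accounts for the size of this step.

From the compounds shown here alone, it remains open whether the modest gain depends on the complete dimethylcarbamoyl group or would also appear with a smaller group at the same position, such as a methyl, a primary amide, an amine or a carboxylic acid. Compounds 2 and 3 each differ from compound 4 in more than one place, so the separate contributions of their substituents also remain unresolved, and single-substituent analogues would be needed to assign them.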